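A few compounds are considered here, and "the series" means these few. Any claim that something is new, unique, unknown or untested is made for them only; others in the source may bear on it.

Measured compounds:
compound 1 `CCCCOC1=CC(=O)c2ccccc2C1=O`: 27000 nM
compound 2 `CC(=O)OC1=CC(=O)c2ccccc2C1=O`: 38800 nM

In a functional assay on KB cells (Homo sapiens) for cytotoxicity (a higher number here means a weaker inhibitor, a lower number a stronger inhibitor), compound 1 gives 27000 nM. Compound 2, which carries acetyl in place of butyl on the same oxygen, gives 38800 nM. For the measured compounds named here, the step of a 1.4-fold higher number from compound 1 to compound 2 (0.16 log units; within the scatter) is small, so compound 2 and compound 1 cannot be told apart on these numbers; compound 2 simply sits at one end of the pair, with compound 1 as its only neighbour.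

Compound 3 `CCOC1=CC(=O)c2ccccc2C1=O` is the next compound, not yet measured. Compared with compound 2 it differs as follows: ethyl in place of acetyl on an oxygen on an unsaturated carbon

Going by the values given here, the only measured step that bears on this position is the exchange on the same oxygen, a 1.4-fold higher number from compound 1 to compound 2 (0.16 log units; within the scatter), which stayed within the scatter. Butyl and acetyl gave indistinguishable numbers there, and ethyl is another small group on that oxygen, so compound 3 is expected to show no step beyond the scatter in this assay. Compound 3 is therefore estimated at 35000 nM, with a range of 15000 nM to 80000 nM. The step from compound 2 to compound 3 expected from this estimate is a 1.1-fold lower number from compound 2 to compound 3 (0.04 log units; within the scatter).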

Compound 3, half-maximal inhibitory concentration: 16900 nM
The estimate for compound 3 lay 2.1-fold (0.32 log units) above the measured number; low and high end bracket the measured number.
By their numbers in this assay, from the lowest: compounds 3, 1 and 2 (each within the scatter of the next, the first and the last beyond it).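

In this assay, for the compounds shown here, the change from acetoxy to ethoxy gives a 2.3-fold lower number from compound 2 to compound 3 (0.36 log units; beyond the scatter), the first step at this oxygen to clear the scatter, so the group placed here can move the number, if only modestly. This does not amount to a clean divide between acetyl and the alkyl groups: shortening the chain from butyl to ethyl gives a 1.6-fold lower number from compound 1 to compound 3 (0.20 log units; within the scatter), which stays within the scatter, and compound 1 also cannot be told apart from compound 2, so it goes against any such divide, and only the two ends of the series are separated. No measurement is available that would explain the step between acetoxy and ethoxy.

With only butyl, ethyl and acetyl on this oxygen, the compounds shown leave open whether the step reflects a real trend or just the gap between the two end members of a narrow series. They also leave open what a longer chain, a benzyl group or a chain ending in an amine or a carboxylic acid would do on this oxygen, and whether any such group could bring the number far below the range seen so far.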